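Swapping the Fluoropiperidine for a Five-Membered Ring

The compounds below may be only part of what the source reports. "The series", "measured", "known", "first", "only" and "open" are said of these compounds alone.

Measured so far in a functional assay on the whole organism (strain balb/c) with Mus musculus as the target, with a stated time of 30 min; on this read-out lower numbers stand for an effect already at smaller amounts and higher numbers for an effect only at larger amounts of compound:
compound 1 `CCN(CC)Cc1cc2c(N)nc(-c3ccco3)nc2s1`: "not determined" (no result reported)
compound 2 `Nc1nc(-c2ccco2)nc2sc(CN3CCC(F)CC3)cc12`: < 1 mg/kg

Compound 2 reaches only a limit of this assay, < 1 mg/kg, so its true dose is not pinned down to a number; this is the limit of < 1 mg/kg in this assay, at which 1 of the 2 values shown sits. Compound 1 has no result in this assay, only the note "not determined" (no result reported). Compound 3 `Nc1nc(-c2ccco2)nc2sc(CN3CC=CC3)cc12` is not yet measured. It differs from compound 2 by a group of 5 heavy atoms (4 carbon, 1 nitrogen; one five-membered non-aromatic ring with 1 hetero atom) in place of a group of 7 heavy atoms (5 carbon, 1 nitrogen, 1 fluorine; one six-membered non-aromatic ring with 1 hetero atom), on a saturated chain carbon bound to an aromatic carbon.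

For the measured compounds named here, no measured step connects two compounds here, so there is nothing to calibrate the change. With both a fluorine and two ring atoms removed, no step beyond the usual scatter is expected in this assay, and a second limit rather than a number seems as likely as not. Compound 3 is therefore estimated at 0.6 mg/kg, within 0.2 mg/kg to 2 mg/kg. That estimate implies a step that the limit leaves unreadable from compound 2 to compound 3, expected to stay inside the scatter.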

Compound 3, dose for half-maximal effect: < 0.1 mg/kg
Compound 3: a limit, no number; the forecaster's own chance of this, stated with the estimate: 60%; middle value at least 6.0-fold (0.77 log units) from the limit.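

For the compounds shown here, compound 2 and compound 3 both give only limits in this assay and not numbers, and no step between them can be read. The compounds shown leave open whether the five-membered non-aromatic ring changes the dose at all relative to 4-fluoropiperidin-1-yl.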